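The compounds below may be only part of what the source reports. "The series", "measured", "known", "first", "only" and "open" are said of these compounds alone.

Compound 3 `CC(C)=CC[C@@H](OC(=O)CC(C)(O)C(C)C)C1=CC(=O)c2c(O)ccc(O)c2C1=O` gives, in a functional assay on DU-145 cells (Homo sapiens) for cytotoxicity, read by MTT assay (on this read-out lower numbers stand for stronger inhibition and higher numbers for weaker inhibition), 16900 nM. Against its two neighbours it holds the top number of the three, but only by a 1.1-fold higher number from compound 1 to compound 3 (0.03 log units; within the scatter) and a 1.3-fold higher number from compound 2 to compound 3 (0.12 log units; within the scatter); compound 1 `CC(=O)OCCC(=O)O[C@H](CC=C(C)C)C1=CC(=O)c2c(O)ccc(O)c2C1=O` gives 15700 nM and compound 2 `CC[C@@](C)(O)CC(=O)O[C@H](CC=C(C)C)C1=CC(=O)c2c(O)ccc(O)c2C1=O` gives 12700 nM. Compound 4 `CC(C)=CC[C@@H](OC(=O)CC(O)c1ccccc1)C1=CC(=O)c2c(O)ccc(O)c2C1=O` differs from compound 3 by hydroxy(phenyl)methyl in place of 1-hydroxy-1,2-dimethylpropyl on a saturated chain carbon bound to a carbonyl carbon. Among the compounds with values here, the steps that bear on this place are a 1.2-fold lower number from compound 1 to compound 2 (0.09 log units; within the scatter), a 1.1-fold higher number from compound 1 to compound 3 (0.03 log units; within the scatter) and a 1.3-fold higher number from compound 2 to compound 3 (0.12 log units; within the scatter), none of them beyond the scatter, so a change at this saturated chain carbon bound to a carbonyl carbon has so far left the read-out essentially unmoved, and compound 4 is expected to show a 1.1-fold lower number from compound 3 to compound 4 (0.05 log units; within the scatter). Compound 4 is therefore estimated at 15000 nM, with a range from 7000 nM to 35000 nM.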

Compound 4, half-maximal inhibitory concentration: 17000 nM
The estimate for compound 4 lay 1.1-fold (0.05 log units) below the measured number; the measured number falls inside the stated range.
By their numbers in this assay, from the lowest: compounds 2, 1, 3 and 4 (each within the scatter of the next).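

Putting an aromatic ring at this place, with hydroxy(phenyl)methyl, leaves the read-out as flat as the open-chain groups did (a 1.0-fold higher number from compound 3 to compound 4 (0.00 log units; within the scatter)), (a 1.3-fold higher number from compound 2 to compound 4 (0.13 log units; within the scatter)) and (a 1.1-fold higher number from compound 1 to compound 4 (0.03 log units; within the scatter)). The four groups on this saturated chain carbon bound to a carbonyl carbon, ring-bearing or not, therefore cannot be told apart here. No evidence at hand explains this flatness. As far as these compounds go, whether an amine, a carboxylic acid or a much longer chain at this place would shift the number stays open.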